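The source may hold more compounds than are shown below. What is called first, only, known or untested is meant among the compounds shown, and "the series" means these compounds.

Compounds measured so far:
- compound 1 `COc1ccc(-c2cc(/C=C/C(=O)c3ccc(N)cc3)[nH]n2)cc1`: 98%
- compound 2 `COc1cc(-c2cc(/C=C/C(=O)c3ccc(N)cc3)[nH]n2)cc(OC)c1OC`: 107%

Both numbers come from a functional assay on IGROV-1 cells (Homo sapiens) for cytotoxicity, read by sulforhodamine B assay, with a stated time of 48 h, tested at 0.01 uM; on this read-out higher numbers stand for a weaker effect at the one concentration tested and lower numbers for a stronger effect. Compound 1 gives 98% and compound 2 gives 107%; the two lie within the scatter of each other, so nothing separates them, and both sit at or near the value that means no effect at the single concentration tested. Compound 2 therefore stands together with compound 1 as a compound without measurable effect in this assay on the numbers shown.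

The next compound is compound 3 `COc1ccc(-c2cc(/C=C/C(=O)c3ccc(N)cc3)[nH]n2)cc1OC`. Against compound 2 the change is hydrogen in place of methoxy on an aromatic carbon. Compound 1 already carries a single methoxy group on that ring and shows the same absence of effect as compound 2, so removing one methoxy group from compound 2 is not expected to move the read-out beyond the scatter in either direction; the step of a number 7 percentage points lower from compound 2 to compound 3 (within the scatter) is expected to be essentially none. Compound 3 is thus estimated at 100% in this assay, with a range of 88% to 112%.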

Compound 3, a percentage reported as activity, at one concentration (the size of the read-out at that concentration, not a potency): 106%
Compound 3: the middle estimate sits 6 percentage points below what was measured, within the range that was stated.
By their numbers in this assay, from the lowest: compounds 1, 3 and 2 (each within the scatter of the next).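

Both one-place steps at this carbon of the ring, ortho to a methoxy group and meta to a large group, can now be read in this assay. Hydrogen in place of methoxy gives a number 1 percentage points lower from compound 2 to compound 3 (within the scatter), and methoxy in place of hydrogen gives a number 8 percentage points higher from compound 1 to compound 3 (within the scatter), so neither direction of this change separates the compounds, whichever neighbouring methoxy pattern it starts from. No measurement shown offers an explanation for these two steps.

Going by these compounds, whether any other group at this carbon, such as a hydroxyl, a fluorine or an amine, would give a read-out beyond the scatter in this assay remains open. Also open, on these data alone, is whether the methoxy change would separate these compounds at another concentration, since a single concentration cannot show this.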